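The compounds below may be only part of what the source reports. "The series", "measured", "known", "first", "only" and "open" are said of these compounds alone.

In a functional assay on the whole organism (strain albino) for inhibition, with Rattus norvegicus as the target, read by paw edema, with stated times of 30 min and 1 h, at a dose of 100 mg/kg by the oral route (on this read-out higher numbers stand for more inhibition at the one dose given (going by the name of the read-out) and lower numbers for less inhibition), the three measured compounds gave the following readings:

Compound 1, `COc1ccc(C2=NN(C(=O)CBr)C(c3c(Cl)cccc3Cl)C2)cc1OC`: 48%
Compound 2, `COc1ccc(C2=NN(C(=O)CO[N+](=O)[O-])C(c3c(Cl)cccc3Cl)C2)cc1OC`: 40%
Compound 3, `COc1ccc(C2=NN(C(=O)C(C)Br)C(c3c(Cl)cccc3Cl)C2)cc1OC`: 51%

Compound 3 gives the highest of the three numbers in this assay; its nearest neighbour is compound 1, with a number 3 percentage points higher from compound 1 to compound 3 (within the scatter), and its furthest is compound 2, with a number 11 percentage points higher from compound 2 to compound 3 (beyond the scatter). Compound 4, `COc1ccc(C2=NN(C(=O)C(C)O[N+](=O)[O-])C(c3c(Cl)cccc3Cl)C2)cc1OC`, has not yet been measured. It differs from compound 3 in one place: nitrooxy in place of bromo on a saturated chain carbon bound to a carbonyl carbon and a saturated chain carbon. Cut one bond further out, the same difference reads 1-bromoethyl to 1-(nitrooxy)ethyl.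

Among the measured compounds shown here, one measured step bears directly on this change: the exchange of bromo for nitrooxy on the unbranched chain, where a number 8 percentage points lower from compound 1 to compound 2 (within the scatter). The branching step itself, with a number 3 percentage points higher from compound 1 to compound 3 (within the scatter), gave no shift beyond the scatter either. On that basis compound 4 is expected to sit a little under compound 3, with a step of a number 8 percentage points lower from compound 3 to compound 4 (within the scatter), again within the scatter. The estimate for compound 4 in this assay is therefore 43%, expected to lie between 33% and 53%.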

Compound 4, a percentage reported as inhibition, in the whole organism at one dose (the size of the read-out at that dose, not a potency): 47%
Estimate against measurement, compound 4: 4 percentage points below; measured number inside the range.
By their numbers in this assay, from the lowest: compounds 2, 4, 1 and 3 (each within the scatter of the next, the first and the last beyond it).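

In this assay, the exchange of bromo for nitrooxy now has a second reading, on the chain carbon that also carries a methyl, with a number 4 percentage points lower from compound 3 to compound 4 (within the scatter), and the two readings agree: the same change on two cores in this assay, a number 8 percentage points lower (within the scatter) from compound 1 to compound 2 and a number 4 percentage points lower (within the scatter) from compound 3 to compound 4, 4 percentage points apart, within the scatter of two such steps. Methyl in place of hydrogen likewise has a second reading, now with nitrooxy on that carbon, with a number 7 percentage points higher from compound 2 to compound 4 (within the scatter), and it agrees with the reading with bromo: the same change on two cores in this assay, a number 3 percentage points higher (within the scatter) from compound 1 to compound 3 and a number 7 percentage points higher (within the scatter) from compound 2 to compound 4, 4 percentage points apart, within the scatter of two such steps. Replacing the whole of bromomethyl with 1-(nitrooxy)ethyl gives a number 1 percentage points lower from compound 1 to compound 4 (within the scatter), so on this route the two changes together leave the number within the scatter.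

The compounds leave open whether a different group on this carbon, such as an amine or a carboxylic acid, or a longer chain in place of the methyl, would shift the number beyond the scatter. With a single dose, they also leave open whether these small steps would hold at other doses.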